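The source may hold more compounds than are shown below. What is called first, only, known or untested is meant among the compounds shown, and "the series" means these compounds.

Two compounds share one core and differ only in the group carried by the amine nitrogen of the six-membered ring with two nitrogen atoms. Compound 1 `CCCn1c(=O)[nH]c2nc(-c3ccc(S(=O)(=O)N4CCN(c5ccc(F)cc5)CC4)cc3)[nH]c2c1=O` carries a 4-fluorophenyl there, and in an assay on CHO cells for displacement of a labelled ligand from adenosine receptor A3 (Homo sapiens), read by scintillation counting, with a stated time of 45 min, in the presence of a further agent that is not named here (a higher number here means a weaker inhibitor, a lower number a stronger inhibitor), compound 1 gives only a limit, > 1000 nM. Compound 2 `CCCn1c(=O)[nH]c2nc(-c3ccc(S(=O)(=O)N4CCN(Cc5ccc(Br)c(F)c5)CC4)cc3)[nH]c2c1=O` carries a 4-bromo-3-fluorobenzyl in that place, and in this assay compound 2 likewise gives only a limit, > 1000 nM. The step that the two limits leave unreadable from compound 1 to compound 2 is therefore not readable, both values sitting at the limit of > 1000 nM in this assay, at which 2 of the 2 values shown sit. Compound 3 `CCCn1c(=O)[nH]c2nc(-c3ccc(S(=O)(=O)N4CCN(c5ccc(I)cc5)CC4)cc3)[nH]c2c1=O` is the next member, and the change is 4-iodophenyl in place of 4-bromo-3-fluorobenzyl on an amine nitrogen in a ring. Within the data shown here, only that one unreadable step bears on it, and it shows no more than that both measured groups on this nitrogen leave the binding too weak to be numbered. The 4-iodophenyl of compound 3 resembles the 4-fluorophenyl of compound 1 in being a phenyl ring on that nitrogen, and compound 1 gave only the limit > 1000 nM. Compound 3 is therefore expected to sit at the limit again, the estimated step that the limit leaves unreadable from compound 2 to compound 3 carrying little meaning. The estimate for compound 3 in this assay is 3000 nM, expected to lie between 800 nM and 20000 nM.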

Compound 3, inhibition constant: > 1000 nM
Compound 3: no number, only a limit; the forecaster's own chance of this, stated with the estimate: 80%; the middle value is on the limit's open side.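

In this assay compound 3, like compound 1 and compound 2, gives only a limit and not a number, so its steps from compound 2 and from compound 1 cannot be read: the limit of > 1000 nM in this assay, at which 3 of the 3 values shown sit. The compounds shown leave open how strongly any of the three binds, and whether the groups on the amine nitrogen differ from one another at all.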